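Varying the amide substituent on a shared core

The source may report more compounds than this note shows. Statements on the series, on what has been measured and on what is new or still open speak of the compounds shown alone.

Measured compounds:
Compound 1, `CCn1c(C(=O)NCCN(C)C)ccc1C(CC)(CC)c1ccc(OCCC(O)(CC)CC)c(C)c1`, gives 1140 nM.
Compound 2, `CCN(CC)CCNC(=O)c1ccc(C(CC)(CC)c2ccc(OCCC(O)(CC)CC)c(C)c2)n1CC`, gives 1630 nM.
Compound 3, `CCOC(=O)C(CC(=O)OC)NC(=O)c1ccc(C(CC)(CC)c2ccc(OCCC(O)(CC)CC)c(C)c2)n1CC`, gives 3020 nM.

These three compounds share one core and differ only in the group attached to an amide-type nitrogen. The numbers come from a functional assay on Caco-2 cells (Homo sapiens) for antiproliferative activity, read by MTT assay, with a stated time of 48 h; on this read-out higher numbers stand for weaker inhibition and lower numbers for stronger inhibition. Compound 2 stands second highest of the three numbers: its nearest neighbour is compound 1, a 1.4-fold higher number from compound 1 to compound 2 (0.16 log units; within the scatter), and the furthest is compound 3, a 1.9-fold higher number from compound 2 to compound 3 (0.27 log units; within the scatter). Within the data shown here, the one step that goes beyond the scatter is a 2.6-fold higher number from compound 1 to compound 3 (0.42 log units; beyond the scatter), a modest move.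

Compound 4, `CCn1c(C(=O)NC(CC(=O)O)C(=O)OC)ccc1C(CC)(CC)c1ccc(OCCC(O)(CC)CC)c(C)c1`, has not yet been measured. It differs from compound 2 in one place: a group of 9 heavy atoms (5 carbon, 4 oxygen; no ring) in place of a group of 7 heavy atoms (6 carbon, 1 nitrogen; no ring), on an amide-type nitrogen. Among the measured compounds shown here, the closest precedent is the move to compound 3, which also exchanges the 2-(diethylamino)ethyl group for a group built from carbon and oxygen only, and that gave a 1.9-fold higher number from compound 2 to compound 3 (0.27 log units; within the scatter). The step from compound 1 to compound 3, a 2.6-fold higher number from compound 1 to compound 3 (0.42 log units; beyond the scatter), points the same way. A small rise in the number, at most modest, is therefore expected for compound 4, a 2.1-fold higher number from compound 2 to compound 4 (0.33 log units; beyond the scatter). The estimate for compound 4 in this assay is 3500 nM, with a likely range from 1500 nM to 8000 nM.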

Compound 4, half-maximal inhibitory concentration: 25200 nM
Estimate against measurement, compound 4: 7.2-fold (0.86 log units) below; measured number above the stated range.
By their numbers in this assay, from the lowest: compounds 1, 2 and 3 (each within the scatter of the next, the first and the last beyond it); then compound 4.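

In this assay, among these compounds, the amide-type nitrogen proves far less forgiving than the earlier compounds suggested, with the new group costing much more than any previous change (a 15-fold higher number from compound 2 to compound 4 (1.19 log units; beyond the scatter); a 22-fold higher number from compound 1 to compound 4 (1.34 log units; beyond the scatter)). The loss of the amine does not by itself set compound 4 apart: the group in compound 3 has no amine either, yet the two amine-free groups are still clearly separated (an 8.3-fold higher number from compound 3 to compound 4 (0.92 log units; beyond the scatter)). As drawn, the group in compound 4 carries a free carboxylic acid and a methyl ester, whereas the group in compound 3 carries only esters, but nothing available here accounts for the large rise in the number.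

The compounds shown leave open whether the carboxylic acid matters in itself, a question that the same group with a second methyl ester in its place could help to answer. They also leave open whether a carboxylic acid at the end of a longer chain, or on a simple two-carbon chain with no ester at all, would give a number as high as that of compound 4.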